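This account rests on a few compounds, and the source may have more. Where it says the series, first, only, none or still open, it means among the compounds named here.

Measured compounds:
Compound 1 `COc1ccc2c(=O)c(/C=C/C(=O)Nc3cc(C)ccc3C)coc2c1` in a functional assay on L02 cells (Homo sapiens) for inhibition, read by MTT assay, with a stated time of 48 h (on this read-out lower numbers stand for stronger inhibition and higher numbers for weaker inhibition), gives > 200000 nM, which is a limit of the assay and not a number.
Compound 2 `COc1cccc(NC(=O)/C=C/c2coc3cc(OC)ccc3c2=O)c1` in this assay gives > 200000 nM, again a limit.
Compound 3 `COc1ccc2c(=O)c(/C=C/C(=O)NCc3ccc(F)cc3)coc2c1` in this assay gives > 200000 nM, again a limit.

Compound 3 therefore stands at the limit, and the same holds for every other value shown: the limit of > 200000 nM in this assay, at which 3 of the 3 values shown sit. The change from compound 3 to compound 4 `COc1ccc2c(=O)c(/C=C/C(=O)Nc3ccccc3C)coc2c1` is 2-methylphenyl in place of 4-fluorobenzyl on an amide-type nitrogen. The measured steps that touch the same amide-type nitrogen are a step that the two limits leave unreadable from compound 1 to compound 3, a step that the two limits leave unreadable from compound 2 to compound 3 and a step that the two limits leave unreadable from compound 1 to compound 2; none of them has a readable size, since each end of each step is a limit. The 2-methylphenyl of compound 4 is closer in kind to the 2,5-dimethylphenyl of compound 1 and the 3-methoxyphenyl of compound 2 than to the 4-fluorobenzyl of compound 3, and all of those compounds sit at the limit. No readable step exists, so no step beyond the scatter in this assay is expected in either direction, and the most likely outcome is that compound 4 again reports only a limit. Compound 4 is expected at 200000 nM, with a range of 100000 nM to 400000 nM. The step that this estimate means is a number no higher from compound 3 to compound 4 (the limit leaves the size open), expected to be nothing beyond the scatter.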

Compound 4, half-maximal inhibitory concentration: > 200000 nM
Compound 4 ended at the assay's limit; the forecaster's own chance of this, stated with the estimate: 85%; the middle value lies on the limit itself.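

Compound 4, like compound 1, compound 2 and compound 3, reports only a limit and not a number in this assay, so no step among these compounds can be read: the limit of > 200000 nM in this assay, at which 4 of the 4 values shown sit.

The compounds shown leave open whether any group on the amide-type nitrogen of the shared core gives a readable value in this assay, and how large any difference between such groups would be.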